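Aryl swap on the triazole nitrogen: series notes

A few compounds are considered here, and "the series" means these few. Any claim that something is new, unique, unknown or untested is made for them only; others in the source may bear on it.

Measured in a functional assay on HCT-116 cells (Homo sapiens) for inhibition, read by sulforhodamine B assay, with a stated time of 48 h, tested at 50 uM; a lower number here means less inhibition of growth, a higher number more inhibition of growth at the concentration tested:
- compound 1 `COc1ccc([C@@H]2C/C(=N/OCc3cn(-c4ccc(O)cc4)nn3)c3cc(CC=C(C)C)c(OC)cc3O2)cc1`: 65%
- compound 2 `COc1ccc([C@@H]2C/C(=N/OCc3cn(-c4ccc(C(=O)c5ccccc5)cc4)nn3)c3cc(CC=C(C)C)c(OC)cc3O2)cc1`: 52%

Not yet measured: compound 3 `COc1ccc([C@@H]2C/C(=N/OCc3cn(-c4ccc(Cl)cc4C)nn3)c3cc(CC=C(C)C)c(OC)cc3O2)cc1`.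

Of the two measured compounds, compound 1 stands highest at 65%, and the gap to compound 2 lies beyond the scatter. The step now in question is from compound 1 to compound 3, which puts 4-chloro-2-methylphenyl in place of 4-hydroxyphenyl on an aromatic nitrogen. The shared core stays unchanged.

Going by the values given here, only one measured step bears on this change: a number 13 percentage points lower from compound 1 to compound 2 (beyond the scatter). That step also alters the aromatic ring on this nitrogen, with benzoyl in place of hydroxy, and it was modest. It is a single step with a different incoming group, so it gives a direction and a rough size but no firm guide. Among the compounds with values here, no measured compound carries chloro or methyl on this ring.

A modest fall in this assay is therefore expected, and a result within the scatter of compound 1 would not be surprising. The expected step is a number 10 percentage points lower from compound 1 to compound 3 (within the scatter). For compound 3 the estimated value is 55%, with an expected range of 40% to 72%.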

Compound 3, percent growth inhibition at one concentration: 20%
Beside the measured number, compound 3's estimate is 35 percentage points above it; the whole stated range lies above it.
By their numbers in this assay, from the lowest: compound 3; then compound 2; then compound 1.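

In this assay, the change to 4-chloro-2-methylphenyl gives a number 45 percentage points lower from compound 1 to compound 3 (beyond the scatter). Going by these compounds alone, this is a large step, whereas the only earlier step on this ring, a number 13 percentage points lower from compound 1 to compound 2 (beyond the scatter), was modest, so the aryl group on this aromatic nitrogen can carry far more of the growth inhibition than that step alone showed. The change removes the hydroxy and brings in chloro and methyl together, so the fall cannot be assigned to any one of these, and no measurement shown here accounts for it.

Still open, from the compounds shown here alone, is how a phenyl ring carrying chloro alone or methyl alone would read in this assay, which would separate the two incoming groups. Also open, going by these compounds, is whether an amine or a carboxylic acid in place of the hydroxy would stay within the scatter of compound 1 at 65% or fall away as compound 3 does at 20%.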